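The source may hold more compounds than are shown below. What is called first, only, known or untested is meant among the compounds shown, and "the series" means these compounds.

Compounds measured:
- compound 1 `CCn1nc(S(=O)(=O)c2cccc3ccccc23)c2cc(N3CCN(C)CC3)ccc21`: 100%
- compound 2 `CCCn1nc(S(=O)(=O)c2cccc3ccccc23)c2cc(N3CCNCC3)ccc21`: 99%
- compound 3 `CN1CCN(c2ccc3c(c2)c(S(=O)(=O)c2cccc4ccccc24)nn3Cc2ccccc2)CC1`: 100%

In a functional assay on HeLa cells for antagonist activity at 5-hydroxytryptamine receptor 6 (Homo sapiens) (a lower number here means a smaller maximal response, a higher number a larger maximal response), compound 3 stands level with compound 1 at the digits shown, the two together at the top of the three numbers; compound 2 lies a single percentage point lower, within the scatter. Among the measured compounds shown here, the series is flat: the one step with a single change, no change at the digits printed from compound 1 to compound 3 (within the scatter), phenyl in place of methyl on a saturated chain carbon bound to an aromatic nitrogen, moved nothing beyond the scatter, and compound 2 differs from compound 1 at two places yet sits at the same level.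

Compound 4 `CC(C)Cn1nc(S(=O)(=O)c2cccc3ccccc23)c2cc(N3CCN(C)CC3)ccc21` carries isopropyl in place of phenyl on a saturated chain carbon bound to an aromatic nitrogen. The step from compound 1 to compound 3 bears on it: the same place, varied from methyl to phenyl, left the maximal response unchanged, and all three measured compounds sit at full response. No effect beyond the scatter is expected in this assay from the change to isopropyl; compound 4 is expected to give 100% (range 92% to 104%), so that no change at the digits printed from compound 3 to compound 4 (within the scatter) is estimated to lie within the scatter.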

Compound 4, largest response reached (reported as Imax), in percent of the reference or control that the assay uses: 100%
The estimate for compound 4 equals the measured number at the digits printed; the range from low to high includes it.
By their numbers in this assay, from the lowest: compounds 2, 1, 3 and 4 (each within the scatter of the next).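

In this assay, the place on a saturated chain carbon bound to an aromatic nitrogen now accepts a branched group without a ring as well as one with a ring: isopropyl in place of phenyl shows no change at the digits printed from compound 3 to compound 4 (within the scatter). Isopropyl in place of methyl reads the same, with no change at the digits printed from compound 1 to compound 4 (within the scatter), so methyl, phenyl and isopropyl at this place are level in this read-out, and neither ring nor branching shows any effect here. No evidence on the origin of this flatness is at hand.

Open, on these data alone, is whether a group carrying a primary amine or a carboxylic acid, or a longer chain such as n-hexyl, at this place would move the maximal response in this assay. Also open, as far as these compounds go, is whether isopropyl behaves the same way on the core of compound 2.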